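A few compounds are considered here, and "the series" means these few. Any claim that something is new, unique, unknown or untested is made for them only; others in the source may bear on it.

Measured compounds in an in vitro functional assay on cells for agonist activity at Bombesin receptor subtype-3 (Homo sapiens), read by luminescence and calcium flux; a higher number here means that more compound is needed for the effect, a lower number that less compound is needed:
compound 1 `O=C(O)c1ccccc1-c1ccc(CCc2ncc(CC3CCCCC3)[nH]2)cc1` — 41 nM
compound 2 `O=C(O)c1ccccc1-c1ccc(CCc2ncc(CC3CCCC3)[nH]2)cc1` — 133 nM
compound 3 `O=C(O)c1ccccc1-c1ccc(CCc2ncc(Cc3ccccc3F)[nH]2)cc1` — 177 nM

Compound 1 gives the lowest number of the three. The nearest step away from it is a 3.2-fold higher number from compound 1 to compound 2 (0.51 log units; beyond the scatter); the furthest is a 4.3-fold higher number from compound 1 to compound 3 (0.64 log units; beyond the scatter). The two larger groups sit close to each other, as a 1.3-fold higher number from compound 2 to compound 3 (0.12 log units; within the scatter) shows.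

Compound 4 `O=C(O)c1ccccc1-c1ccc(CCc2ncc(Cc3ccc(F)cc3)[nH]2)cc1` is not yet measured. It differs from compound 1 in one place: 4-fluorophenyl in place of cyclohexyl on a saturated chain carbon bound to an aromatic carbon. The step that bears most directly on this change is a 4.3-fold higher number from compound 1 to compound 3 (0.64 log units; beyond the scatter), where a 2-fluorophenyl likewise replaced cyclohexyl on a saturated chain carbon bound to an aromatic carbon. The step of a 3.2-fold higher number from compound 1 to compound 2 (0.51 log units; beyond the scatter) adds that cyclohexyl gave the lowest number in this set and that exchanging it for either alternative raised the number by a modest amount. A modest rise in this assay is therefore expected for compound 4, about the size seen for compound 3 and beyond the scatter. The expected step is a 3.7-fold higher number from compound 1 to compound 4 (0.56 log units; beyond the scatter). Compound 4 is estimated at 150 nM, with a range of 60 nM to 400 nM.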

Compound 4, half-maximal effective concentration: 1600 nM
Compound 4: the middle estimate sits 11-fold (1.03 log units) below what was measured; measured number above the stated range.
By their numbers in this assay, from the lowest: compound 1; then compounds 2 and 3 (each within the scatter of the next); then compound 4.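

In this assay, the identity of the fluorophenyl group on this saturated chain carbon matters far more than compound 3 alone suggested: 4-fluorophenyl in place of 2-fluorophenyl gives a 9.0-fold higher number from compound 3 to compound 4 (0.96 log units; beyond the scatter). Against the saturated rings, the change costs more than any earlier step, with a 39-fold higher number from compound 1 to compound 4 (1.59 log units; beyond the scatter) and a 12-fold higher number from compound 2 to compound 4 (1.08 log units; beyond the scatter). The modest rises seen so far therefore do not hold for every replacement of cyclohexyl, and an aromatic ring in place of a saturated one does not by itself set the number, since compound 3 stays within the scatter of compound 2 while compound 4 does not.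

Nothing available accounts for the size of these steps. Whether the rise belongs to the fluorine or to the ring could be tested with an unsubstituted phenyl or a chlorophenyl at this place.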